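Series notes: shortening the alkenyl chain of compound 2

This account rests on a few compounds, and the source may have more. Where it says the series, first, only, none or still open, it means among the compounds named here.

Compound 1 `CCCCn1c(Cc2c(Br)c(OC)c(OC)c(OC)c2Br)nc2c(N)ncnc21`: 30200 nM in a functional assay on MCF7 cells (Homo sapiens) for antiproliferative activity; on this read-out higher numbers stand for weaker inhibition and lower numbers for stronger inhibition.
Compound 2 `CC/C=C\Cn1c(Cc2cc(OC)c(OC)c(OC)c2)nc2c(N)ncnc21`: 64600 nM in this assay.
Compound 3 `CCCCn1c(Cc2cc(OC)c(OC)c(OC)c2Br)nc2c(N)ncnc21`: 25100 nM in this assay.

Compound 2 gives the highest number of the three; compound 1 lies below it beyond the scatter, and compound 3 further below still. Among the compounds with values here, the only measured step, a 1.2-fold lower number from compound 1 to compound 3 (0.08 log units; within the scatter), concerns hydrogen in place of bromo on an aromatic carbon and carries no information about the chain on the aromatic nitrogen. Compound 4 `C=CCCn1c(Cc2cc(OC)c(OC)c(OC)c2)nc2c(N)ncnc21` differs from compound 2 by allyl in place of but-1-en-1-yl on a saturated chain carbon bound to an aromatic nitrogen. Within the data shown here, no measured pair shows a change of this kind, so the expected step is none beyond the scatter, taken as a 1.1-fold lower number from compound 2 to compound 4 (0.03 log units; within the scatter). Compound 4 is therefore estimated at 60000 nM in this assay, with an expected range from 25000 nM to 150000 nM.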

Compound 4, half-maximal inhibitory concentration: 40700 nM
For compound 4 the middle estimate is 1.5-fold (0.17 log units) above the measured one; measured number inside the range.
By their numbers in this assay, from the lowest: compounds 3, 1, 4 and 2 (each within the scatter of the next, the first and the last beyond it).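

Within the data shown here, on the saturated chain carbon bound to an aromatic nitrogen, allyl in place of but-1-en-1-yl gives a 1.6-fold lower number from compound 2 to compound 4 (0.20 log units; within the scatter) in this assay, the first measured step at this position. The two alkenyl chains are therefore not separated by this read-out. No supporting data bear on this result.

Going by these compounds, whether an amine or a carboxylic acid on this chain, or a longer chain, would give a step beyond the scatter remains open. Also open, on these data alone, is how butyl, carried by compound 1 and compound 3, compares with these alkenyl chains on an otherwise identical compound.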